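Methyl on the Ring Amine and Agonist Response

A few compounds are considered here, and "the series" means these few. Any claim that something is new, unique, unknown or untested is made for them only; others in the source may bear on it.

Compound 1, `Fc1ccc(C2=CC3CNCC(C2)C3)cn1`, was examined in an in vitro functional assay on SH-EP1 cells for agonist activity at Neuronal acetylcholine receptor; alpha4/beta2 (Homo sapiens), read by FLIPR and calcium flux (on this read-out lower numbers stand for smaller maximal responses and higher numbers for larger maximal responses), where compound 1 reached 104%. Compound 2, `C1=C(c2cccnc2)C[C@@H]2CNC[C@H]1C2`, shares the same kind of bridged amine but carries a different pyridine; the difference between the two cores is not broken down here. In this assay compound 2 gave 111%, a value that lies within the scatter of the value for compound 1, so the two are treated as equal.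

Compound 3, `CN1CC2C=C(c3ccc(F)nc3)CC(C2)C1`, differs from compound 1 by one change, (methyl in place of hydrogen on an amine nitrogen in a ring). In this assay, among the measured compounds shown here, compound 3 gave 22%, and the step of a number 82 percentage points lower from compound 1 to compound 3 (beyond the scatter) is the only step within the set that reaches beyond the scatter.

Compound 4, `CN1C[C@@H]2C=C(c3cccnc3)C[C@@H](C2)C1`, has not yet been measured. It stands to compound 2 as compound 3 stands to compound 1: the change is methyl in place of hydrogen on an amine nitrogen in a ring, and this change occurs twice among the compounds shown, each time at the same place on the same kind of ring. Since the step of a number 82 percentage points lower from compound 1 to compound 3 (beyond the scatter) was large and the cores of compound 1 and compound 2 gave values within the scatter of each other, a step of similar size is expected, a number 83 percentage points lower from compound 2 to compound 4 (beyond the scatter). On that basis compound 4 is estimated to reach 28% in this assay, with a range from 10% to 55%.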

Compound 4, largest response reached (reported as percent of maximum), in percent of the reference or control that the assay uses: 53%
Estimate against measurement, compound 4: 25 percentage points below, within the range that was stated.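

On the second core, methyl in place of hydrogen on an amine nitrogen in a ring again gave a lower response in this assay, a number 58 percentage points lower from compound 2 to compound 4 (beyond the scatter), so the direction of the change held on both cores shown. The size of the step did not carry over unchanged: the same change on two cores in this assay, a number 82 percentage points lower (beyond the scatter) from compound 1 to compound 3 and a number 58 percentage points lower (beyond the scatter) from compound 2 to compound 4, 24 percentage points apart, beyond the scatter of two such steps The two pairs therefore show that, within this small set, the direction can be carried from one core to the other while the size of the step on one core does not fix its size on the other, but they do not show which difference between the cores goes with the gap, or whether the same direction would hold on any further core.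

The compounds shown leave open whether an ethyl group or a longer chain on the same amine nitrogen would give a response like that of the methyl compounds or a different one. They also leave open how the same methyl change would behave on a core carrying chlorine or a methoxy group on the pyridine, and so how far the direction seen on these two cores extends within the series.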